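Replacing 2-Bromophenyl with 4-Methylphenyl: an Expected Lipophilicity

This account rests on a few compounds, and the source may have more. Where it says the series, first, only, none or still open, it means among the compounds named here.

Of the compounds shown here, three that share one core have been measured in a physicochemical assay for lipophilicity, measured as octanol-water partition; on this read-out higher numbers stand for higher lipophilicity and lower numbers for lower lipophilicity. Compound 1 `O=C(COc1cccc2ccccc12)N/N=C/c1ccc(O)cc1` gives 3.73, compound 2 `O=C(COc1cccc2ccccc12)N/N=C/c1ccccc1[N+](=O)[O-]` gives 3.97, and compound 3 `O=C(COc1cccc2ccccc12)N/N=C/c1ccccc1Br` gives 4.81, the highest of the three, with compound 2 nearest and compound 1 furthest below it. Two steps lead to compound 3: a number 1.08 log units higher from compound 1 to compound 3 (beyond the scatter) and a number 0.84 log units higher from compound 2 to compound 3 (beyond the scatter). Compound 4 `Cc1ccc(/C=N/NC(=O)COc2cccc3ccccc23)cc1` is not yet measured; the change from compound 3 is 4-methylphenyl in place of 2-bromophenyl on a carbon with a double bond to nitrogen. Neither measured step shows a methyl group entering, so they give only indirect guidance: both show that 2-bromophenyl sits at the high end. A small decrease, within or close to the scatter, is expected, namely a number 0.31 log units lower from compound 3 to compound 4 (beyond the scatter). Compound 4 is therefore estimated at 4.5, between 4.1 and 4.9.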

Compound 4, partition coefficient: 4.49
Beside the measured number, compound 4's estimate is 0.01 log units above it; measured number inside the range.
By their numbers in this assay, from the lowest: compounds 1 and 2 (each within the scatter of the next); then compound 4; then compound 3.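

In this assay, 4-methylphenyl in place of 2-bromophenyl on a carbon with a double bond to nitrogen gives a number 0.32 log units lower from compound 3 to compound 4 (beyond the scatter), so this position can hold a group without bromine and stay above compound 1 and compound 2. Methyl in place of hydroxy on an aromatic carbon gives a number 0.76 log units higher from compound 1 to compound 4 (beyond the scatter), the first step here with methyl entering. Nothing shown explains either step. The first step changes both the group and where it sits, and 2-methylphenyl or 4-bromophenyl would be needed to separate the two. As far as these compounds go, how a ring carrying an amine or a carboxylic acid would compare remains open.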